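A Second Halogen on the Fused Ring of Compound 1

The source may report more compounds than this note shows. Statements on the series, on what has been measured and on what is new or still open speak of the compounds shown alone.

Compound 1, `NC(=O)[C@@H](c1ccccc1)N(C(=O)c1ccccc1)[C@@H]1CCc2c(F)cccc21`, gives 120 nM in an assay on HEK293T cells for antagonist activity at transient receptor potential cation channel subfamily M member 8 (Homo sapiens), read by fluorescence and calcium flux, with a stated time of 60 min; a lower number here means a stronger inhibitor, a higher number a weaker inhibitor. For the measured compounds named here, that is the lowest of the two numbers measured so far. Its nearest neighbour is compound 2, `NC(=O)[C@@H](c1ccccc1)N(C(=O)c1ccccc1)[C@@H]1CCc2c(Cl)cccc21`, which gives 720 nM, and the step of a 6.0-fold higher number from compound 1 to compound 2 (0.78 log units; beyond the scatter) shows that exchanging the halogen on the fused ring changes the result clearly. Compound 3, `NC(=O)[C@@H](c1ccccc1)N(C(=O)c1ccccc1)[C@@H]1CCc2c(F)cc(Cl)cc21`, is not yet measured. It keeps the fluoro group of compound 1 and gains a second halogen: chloro in place of hydrogen on an aromatic carbon, meta to a fluoro group. Going by the values given here, no measured step covers adding a group at that place. Among the compounds with values here, the only step in hand is a replacement at a different position, so it bears on compound 3 only loosely. A modest weakening is expected, and the step of a 2.1-fold higher number from compound 1 to compound 3 (0.32 log units; beyond the scatter) is the estimate. Compound 3 is expected to give 250 nM, within a range from 80 nM to 900 nM.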

Compound 3, half-maximal inhibitory concentration: 300 nM
Compound 3: the middle estimate sits 1.2-fold (0.08 log units) below what was measured, and the stated range covers the measured number.
By their numbers in this assay, from the lowest: compound 1; then compound 3; then compound 2.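

In this assay there is a 2.5-fold higher number from compound 1 to compound 3 (0.40 log units; beyond the scatter) when chloro replaces hydrogen on this aromatic carbon, meta to a fluoro group. For the compounds shown here, the earlier step only exchanged one halogen for another at a different carbon, so this is the first sign that adding a group at this place also raises the number, though by a modest amount. The cause of that rise cannot be told, as no measurement shown here bears on it.

As far as these compounds go, it remains open whether the rise is particular to chloro or would also follow from another group on this carbon, such as an amine, a methoxy group or a nitrile. It is also unknown whether chloro here would have the same effect on compound 2, which carries chloro rather than fluoro on the fused ring.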